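The source may report more compounds than this note shows. Statements on the series, on what has been measured and on what is new or still open speak of the compounds shown alone.

Compound 1 `CC(C)=CCC1Cc2c(OC(=O)Nc3ccc(F)c(F)c3)cc(=O)n(CCCO)c2CC1(C)C` and compound 2 `COc1ccccc1NC(=O)Oc1cc(=O)n(CCCO)c2c1CC(C/C=C(\C)CCC=C(C)C)C(C)(C)C2` share a core and differ in the group on the amide-type nitrogen. In a functional assay on PANC-1 cells (Homo sapiens) for inhibition, read by MTT assay, with a stated time of 24 h, tested at 10 uM (on this read-out higher numbers stand for more inhibition at the one concentration tested (going by the name of the read-out) and lower numbers for less inhibition), compound 1 gives 0%, and compound 2 gives 0%, so compound 2 stands level with compound 1 within the scatter. Compound 3 `CC(C)=CCC/C(C)=C/CC1Cc2c(OC(=O)Nc3ccc(F)c(F)c3)cc(=O)n(CCCO)c2CC1(C)C` is not yet measured; it differs from compound 2 by 3,4-difluorophenyl in place of 2-methoxyphenyl on an amide-type nitrogen. Among the measured compounds shown here, the 3,4-difluorophenyl group that enters is the one compound 1 already carries on an amide-type nitrogen. No step beyond the scatter is expected, because compound 1 gives 0% in this assay. Compound 3 is therefore expected to give 0% in this assay, between 0% and 10%. The expected step of no change at the digits printed from compound 2 to compound 3 (within the scatter) would stay within the scatter.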

Compound 3, a percentage reported as inhibition, at one concentration (the size of the read-out at that concentration, not a potency): 4.8%
For compound 3 the middle estimate is 4.8 percentage points below the measured one; the range from low to high includes it.
By their numbers in this assay, from the lowest: compounds 1, 2 and 3 (each within the scatter of the next).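

In this assay the 3,4-difluorophenyl in place of 2-methoxyphenyl on an amide-type nitrogen gives a number 4.8 percentage points higher from compound 2 to compound 3 (within the scatter) and so, even with the chain also differing, this swap does not move the read-out beyond normal variation. Putting 3-methylbut-2-en-1-yl in place of hydrogen on a saturated chain carbon bound to a double-bonded chain carbon gives a number 4.8 percentage points higher from compound 1 to compound 3 (within the scatter) and likewise stays within that variation. On these data alone, whether an amine or a carboxylic acid on the aromatic ring would give a clearly higher number remains open. Nothing available offers an explanation for these readings.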